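Compound 4: an Aminoalkyl Chain on the Aromatic Nitrogen

The source may report more compounds than this note shows. Statements on the series, on what has been measured and on what is new or still open speak of the compounds shown alone.

Compound 1 `O=C1c2c[n+]([O-])c3ccccc3c2C(=O)c2[nH]c3ccccc3c21` is the parent of this small set. In a toxicity assay on L02 cells (Homo sapiens) for cytotoxicity, read by MTT assay, with a stated time of 72 h (on this read-out lower numbers stand for stronger inhibition and higher numbers for weaker inhibition), compound 1 gives 400 nM, the second highest of the three numbers recorded. Compound 2 `CC1(C)OCC(Cn2cc(Cn3c4c(c5ccccc53)C(=O)c3c[n+]([O-])c5ccccc5c3C4=O)nn2)O1` gives 120 nM in this assay, and compound 3 `CC1(C)OC[C@H](Cn2cc(Cn3c4c(c5ccccc53)C(=O)c3c[n+]([O-])c5ccccc5c3C4=O)nn2)O1` gives 470 nM. Among the measured compounds shown here, the one step between measured compounds, a 3.9-fold higher number from compound 2 to compound 3 (0.59 log units; beyond the scatter), concerns the fact that one of compounds 2 and 3 is drawn with a defined configuration and the other without, at the place where they differ and does not bear on the change considered here. Compound 4 `CN(C)CCCCCn1c2c(c3ccccc31)C(=O)c1c[n+]([O-])c3ccccc3c1C2=O` differs from compound 1 by 5-(dimethylamino)pentyl in place of hydrogen on an aromatic nitrogen. For the measured compounds named here, no measured pair tests this chain directly; the values of compounds 2 and 3 show only that a substituent on the same nitrogen can leave the number in the range of compound 1 or take it below. The number for compound 4 is therefore expected to sit near that range, as a 1.6-fold lower number from compound 1 to compound 4 (0.20 log units; within the scatter), with an estimate of 250 nM between 80 nM and 800 nM.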

Compound 4, half-maximal inhibitory concentration: 240 nM
For compound 4 the middle estimate is 1.0-fold (0.02 log units) above the measured one; the range from low to high includes it.
By their numbers in this assay, from the lowest: compounds 2, 4, 1 and 3 (each within the scatter of the next, the first and the last beyond it).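

In this assay the first direct test of a chain on this aromatic nitrogen gives a 1.7-fold lower number from compound 1 to compound 4 (0.22 log units; within the scatter), so no change can be read. The hydrogen there can thus give way to 5-(dimethylamino)pentyl while the number stays within the scatter of that of compound 1. Nothing at hand bears on why this step is so small.

The compounds shown leave open whether this holds for other chains on the same nitrogen. A shorter propyl chain, a morpholine at the chain end or a terminal carboxylic acid could each behave differently.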